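Bromo-to-fluoro swap on the pendant aryl ring

A few compounds are considered here, and "the series" means these few. Any claim that something is new, unique, unknown or untested is made for them only; others in the source may bear on it.

Measured so far:
compound 1 `CC(=O)Oc1ccc(/C=C/C(=O)OCCSc2nc(-c3ccc(S(C)(=O)=O)cc3)n(-c3ccc(F)cc3)n2)cc1OC(C)=O` — 11800 nM
compound 2 `CS(=O)(=O)c1ccc(-c2nc(SCCCOC(=O)/C=C/c3ccc(O)c(O)c3)nn2-c2ccc(Br)cc2)cc1` — 11200 nM

In a functional assay on A549 cells (Homo sapiens) for antiproliferative activity, read by MTT assay, with a stated time of 72 h (on this read-out lower numbers stand for stronger inhibition and higher numbers for weaker inhibition), compound 2 gives 11200 nM, the lowest of the two numbers in hand. In this assay compound 1 gives 11800 nM, a number within the scatter of that of compound 2, so the two values show no order between them. Among the measured compounds shown here, no step between measured compounds that differ in one place is available, and compound 1 and compound 2 differ in more than one place, so only their two values can be read side by side.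

Compound 3 `CS(=O)(=O)c1ccc(-c2nc(SCCCOC(=O)/C=C/c3ccc(O)c(O)c3)nn2-c2ccc(F)cc2)cc1` is not yet measured. It differs from compound 2 by fluoro in place of bromo on an aromatic carbon, a single-atom exchange on an aromatic carbon, para to a large group. The rest of the core of compound 2 is kept. Without a measured step of this kind in the series, no direction can be drawn from the data; the working expectation for this assay is a step of a 1.1-fold higher number from compound 2 to compound 3 (0.03 log units; within the scatter), that is, none beyond the scatter. Compound 3 is therefore estimated at 12000 nM, with a range from 5000 nM to 30000 nM.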

Compound 3, half-maximal inhibitory concentration: 9520 nM
Compound 3: middle estimate off by 1.3-fold (0.10 log units), on the high side; the range from low to high includes it.
By their numbers in this assay, from the lowest: compounds 3, 2 and 1 (each within the scatter of the next).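

Fluoro in place of bromo, on an aromatic carbon para to a large group, gives the first step in the series between compounds that differ in one place: in this assay there is a 1.2-fold lower number from compound 2 to compound 3 (0.07 log units; within the scatter). The 4-bromophenyl and 4-fluorophenyl forms therefore cannot be told apart in this read-out, so the choice between these two halogens at this position shows no order here, a reading that compound 1 and compound 2 could not give because they differ in more than one place. No measurement in hand bears on why the two halogens read alike.

Going by these compounds, a single exchange between two halogens says little about the position as a whole, so it remains open whether a different group there, such as an amine, a methoxy group or a carboxylic acid, would give a step beyond the scatter. Also open, on these data alone, are the separate contributions of the chain and the two acetate esters on the catechol ring, which compound 1 carries together with other differences from compound 3, and whether a longer chain would shift the number in this assay.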